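Sulfonamide variation on the shared core

A few compounds are considered here, and "the series" means these few. Any claim that something is new, unique, unknown or untested is made for them only; others in the source may bear on it.

Compound 1 `CC1(C)C=C(n2ccccc2=O)c2cc(S(=O)(=O)N=[N+]=[N-])ccc2O1` and compound 2 `CC(C)NS(=O)(=O)c1ccc2c(c1)C(n1ccccc1=O)=CC(C)(C)O2` share one core and differ only at the sulfonyl sulfur. Among the compounds with values here, in a functional assay with Rattus norvegicus as the target (on this read-out higher numbers stand for an effect only at larger amounts of compound and lower numbers for an effect already at smaller amounts), compound 1 gives 16.2 nM and compound 2 gives 676 nM, the higher of the two numbers; the only measured step, a 42-fold higher number from compound 1 to compound 2 (1.62 log units; beyond the scatter), is this same exchange of azido for isopropylamino. Compound 3 `CC1(C)C=C(n2ccccc2=O)c2cc(S(=O)(=O)Nc3ccc([N+](=O)[O-])cc3)ccc2O1` differs from compound 2 by 4-nitrophenyl in place of isopropyl on a sulfonamide nitrogen. Within the data shown here, no measured step exchanges one substituent on a sulfonamide nitrogen for another, so the direction in this assay stays open and the range is kept wide. For compound 3 a number near 250 nM is expected, within 40 nM to 2000 nM. This estimate means an expected step of a 2.7-fold lower number from compound 2 to compound 3 (0.43 log units; beyond the scatter).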

Compound 3, half-maximal effective concentration: 2090 nM
Compound 3: middle estimate off by 8.4-fold (0.92 log units), on the low side; measured number outside the range, above it.
By their numbers in this assay, from the lowest: compound 1; then compound 2; then compound 3.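

Within the data shown here, the first exchange of one substituent for another on a sulfonamide nitrogen, in this assay, gives a 3.1-fold higher number from compound 2 to compound 3 (0.49 log units; beyond the scatter) for 4-nitrophenyl in place of isopropyl, so this larger aromatic group does not lower the number. Compared with azido on the sulfonyl sulfur, (4-nitrophenyl)amino gives a 130-fold higher number from compound 1 to compound 3 (2.11 log units; beyond the scatter) and leaves compound 1 lowest of the three. No evidence accompanies these numbers to explain the change. From the compounds shown here alone, whether the step belongs to the ring or the nitro group stays open, and phenyl on the sulfonamide nitrogen would separate the two. Plain amino on the sulfonyl sulfur would show where the unsubstituted sulfonamide falls.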